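The source may hold more compounds than are shown below. What is called first, only, known or untested is meant among the compounds shown, and "the series" means these compounds.

Compound 1 `COc1ccc(Cn2cc(CNC(=O)c3cn(-c4ccccc4)nc3-c3ccc(F)cc3)nn2)cc1` carries a fluoro group on one ring, and in a functional assay on MCF7 cells (Homo sapiens) for antiproliferative activity, read by sulforhodamine B assay, with a stated time of 48 h (a higher number here means a weaker inhibitor of growth, a lower number a stronger inhibitor of growth), compound 1 gives 650 nM. Compound 2 `COc1ccc(Cn2cc(CNC(=O)c3cn(-c4ccccc4)nc3-c3ccc(F)cc3)nn2)cc1OC` adds a methoxy group, described as methoxy in place of hydrogen on an aromatic carbon. In this assay compound 2 reaches only a limit of the assay, > 100000 nM; the step of an at least 150-fold higher number from compound 1 to compound 2 (2.18 log units; beyond the scatter) is therefore read against (the limit of > 100000 nM in this assay, at which 1 of the 3 values shown sits). Compound 3 `COc1ccc(Cn2cc(CNC(=O)c3cn(-c4ccccc4)nc3-c3ccc(Cl)cc3)nn2)cc1` differs from compound 1 in its core, (chloro in place of fluoro on an aromatic carbon), and in this assay compound 3 gives 8000 nM, a step of a 12-fold higher number from compound 1 to compound 3 (1.09 log units; beyond the scatter).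

Compound 4 `COc1ccc(Cn2cc(CNC(=O)c3cn(-c4ccccc4)nc3-c3ccc(Cl)cc3)nn2)cc1OC` makes the same change to compound 3, (methoxy in place of hydrogen on an aromatic carbon), that compound 2 made to compound 1. Compound 4 is expected to show a step of about a 19-fold higher number from compound 3 to compound 4 (1.27 log units; beyond the scatter), which rests on an at least 150-fold higher number from compound 1 to compound 2 (2.18 log units; beyond the scatter). The estimate for compound 4 in this assay is 150000 nM, between 30000 nM and 1000000 nM.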

Compound 4, concentration for 50% growth inhibition: > 100000 nM
Compound 4 was reported as a limit; the forecaster's own chance of this, stated with the estimate: 75%; the middle value does not contradict the limit.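

Adding the methoxy group to compound 3 again gives a weaker inhibitor of growth in this assay, a step of an at least 12-fold higher number from compound 3 to compound 4 (1.09 log units; beyond the scatter), so the change points the same way with chloro as with fluoro. Compound 4 gives only a limit of the assay, > 100000 nM, and the steps between the two limit compounds cannot be read. The direction therefore carries over from one core to the other, but the size of the change on each core does not follow from these values: the same change on two cores in this assay, an at least 150-fold higher number (2.18 log units; beyond the scatter) from compound 1 to compound 2 and an at least 12-fold higher number (1.09 log units; beyond the scatter) from compound 3 to compound 4; the limit leaves it open whether they differ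

The compounds shown leave open whether a hydroxy group or an amine in the same place would also weaken growth inhibition. They also leave open how a bromo group in place of the chloro would behave.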